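The source may report more compounds than this note shows. Statements on the series, on what has been measured and on what is new or still open speak of the compounds shown alone.

Compound 3 `CCOC(=O)CCCCCOc1cccc(CN(C(=O)c2ccc(-c3cccc(OCC)c3)cc2)C(C)C)c1` is one of three compounds tested in an ADME assay on HEK293 cells (Homo sapiens) for cytotoxicity, read by CellTiter-Glo and resazurin assay, with a stated time of 72 h; a higher number here means that more compound is needed for the effect, a lower number that less compound is needed. In this assay compound 3 reached only the limit of > 22300 nM. Compound 1 `CCOC(=O)CCCCCOc1cccc(CN(C(=O)c2ccc(-c3ccco3)cc2)C(C)C)c1` likewise stopped at a limit, > 26000 nM. Compound 2 `CCOC(=O)CCCCCOc1cccc(CN(C(=O)c2ccc(-c3cccc(-c4nnc(C)o4)c3)cc2)C(C)C)c1` also gave no number but a limit, > 26000 nM. The steps a step that the two limits leave unreadable from compound 1 to compound 3 and a step that the two limits leave unreadable from compound 2 to compound 3 therefore cannot be read, as the limit of > 22300 nM in this assay, at which 1 of the 3 values shown sits, and the limit of > 26000 nM in this assay, at which 2 of the 3 values shown sit, show; the same holds for a step that the two limits leave unreadable from compound 1 to compound 2. Compound 4 `CCOC(=O)CCCCCOc1cccc(CN(C(=O)c2ccc(-c3cccc(CC(=O)O)c3)cc2)C(C)C)c1` is made from compound 3 by the change (carboxymethyl in place of ethoxy on an aromatic carbon). For the measured compounds named here, no measured step shows which way this change moves the read-out, so the three limits are the only guide. Compound 4 is thus expected to sit at or beyond the limit again, around 30000 nM, between 15000 nM and 100000 nM. For compound 4 the expected step is a step that the limit leaves unreadable from compound 3 to compound 4.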

Compound 4, half-maximal effective concentration: > 26000 nM
Compound 4: a limit, no number (the forecaster's own chance of this, stated with the estimate: 80%); the middle value does not contradict the limit.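

For the compounds shown here, compound 4 again gives only a limit, so no step between it and compound 1, compound 2 or compound 3 can be read: the limit of > 26000 nM in this assay, at which 3 of the 4 values shown sit. In this assay, the compounds shown leave open which way any of these changes moves the read-out.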